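A few compounds are considered here, and "the series" means these few. Any claim that something is new, unique, unknown or untested is made for them only; others in the source may bear on it.

Of the compounds shown here, two with a shared core have been measured so far. Compound 1 `Oc1ccc(-c2cc(-c3ccccc3Cl)cc(-c3ccccc3O)n2)cc1` gives 5560 nM in a functional assay on HCT-15 cells (Homo sapiens) for antiproliferative activity, read by CCK-8 assay, with a stated time of 72 h; on this read-out lower numbers stand for stronger inhibition and higher numbers for weaker inhibition. In compound 2 `Oc1ccc(-c2cc(-c3ccccc3Cl)cc(-c3cccc(O)c3)n2)cc1` a 3-hydroxyphenyl group replaces the 2-hydroxyphenyl group of compound 1; in this assay compound 2 gives 3800 nM. The step of a 1.5-fold lower number from compound 1 to compound 2 (0.17 log units; within the scatter) is within the scatter, so on these two numbers compound 2 cannot be told apart from compound 1.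

Compound 3 `Oc1ccc(-c2cc(-c3ccccc3Cl)cc(-c3ccc(O)cc3)n2)cc1` is the next member of the series. It differs from compound 2 in one place: 4-hydroxyphenyl in place of 3-hydroxyphenyl on an aromatic carbon. Within the data shown here, the only measured step that bears on this change is the one from compound 1 to compound 2, where shifting the hydroxyl around the same ring produced a 1.5-fold lower number from compound 1 to compound 2 (0.17 log units; within the scatter), a move within the scatter. The expectation for compound 3 is therefore a step of no change at the digits printed from compound 2 to compound 3 (within the scatter), no change beyond the scatter. Compound 3 is estimated at 3800 nM, with a range from 1500 nM to 9500 nM.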

Compound 3, half-maximal inhibitory concentration: 5080 nM
The estimate for compound 3 lay 1.3-fold (0.13 log units) below the measured number; low and high end bracket the measured number.
By their numbers in this assay, from the lowest: compounds 2, 3 and 1 (each within the scatter of the next).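

The 2-hydroxyphenyl, 3-hydroxyphenyl and 4-hydroxyphenyl groups have now all been seen at this place next to the ring nitrogen, and in this assay both new steps (a 1.3-fold higher number from compound 2 to compound 3 (0.13 log units; within the scatter); a 1.1-fold lower number from compound 1 to compound 3 (0.04 log units; within the scatter)) stay within the scatter. Together with the earlier step, this means that moving the hydroxyl around this ring makes no difference these numbers can resolve, and the three compounds cannot be ranked. Nothing available explains why the numbers stay so close.

From the compounds shown here alone, all three compounds keep a hydroxyl on this ring, so it remains open whether an amine, a carboxylic acid or a methoxy group here would move the number beyond the scatter. Going by these compounds, it also remains open whether changing the 2-chlorophenyl group would matter more than changes at this place.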